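The compounds below may be only part of what the source reports. "The series", "measured", "known", "first", "only" and "open" are said of these compounds alone.

In a physicochemical assay for lipophilicity, read by HPLC, at pH 7.4 (a higher number here means a more lipophilic compound, a lower number a more polar compound), the compounds read as follows:
Compound 1 `CCC/N=C1\S/C(=C\c2ccc(O)cn2)C(=O)N1c1ccccc1C` reads 3
Compound 2 `CCC/N=C1\S/C(=C\c2ccc(O)c(Br)c2)C(=O)N1c1ccccc1C` reads 3.9
Compound 3 `CCC/N=C1\S/C(=C\c2ccc(O)c(Cl)c2)C(=O)N1c1ccccc1C` is not yet measured

Compound 2 at 3.9 stands highest of the two measured compounds. Compound 3 differs from compound 2 in one place: chloro in place of bromo on an aromatic carbon that is, chloro in place of bromo on an aromatic carbon, ortho to a hydroxy group. For the measured compounds named here, the only measured step, a number 0.90 log units higher from compound 1 to compound 2 (beyond the scatter) in size, exchanged a whole aromatic group, so it bears only loosely on this change. A much smaller, downward step is expected in this assay here, estimated as a number 0.20 log units lower from compound 2 to compound 3 (within the scatter) and probably within the scatter. For compound 3 the expected value is 3.7 with a range of 3.4 to 4 in this estimate.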

Compound 3, distribution coefficient: 3.8
Estimate against measurement, compound 3: 0.10 log units below, and the stated range covers the measured number.
By their numbers in this assay, from the lowest: compound 1; then compounds 3 and 2 (each within the scatter of the next).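

In this assay, chloro in place of bromo on an aromatic carbon ortho to a hydroxy group gives a number 0.10 log units lower from compound 2 to compound 3 (within the scatter) and so leaves these two halogens undistinguished at this position. The separation from the hydroxypyridine compound holds with chloro as it did with bromo, with a number 0.80 log units higher from compound 1 to compound 3 (beyond the scatter) as the step. Nothing available offers a reason for either reading.

Going by these compounds, whether fluoro, methyl or methoxy on that carbon would read like chloro and bromo stays open. So does the effect of an amine or a carboxylic acid in place of the hydroxy group.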